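The source may report more compounds than this note shows. Statements on the series, on what has been measured and on what is new or still open speak of the compounds shown alone.

Measured so far:
compound 1 `COc1cccc(CNCCCNc2ccnc3cc(-c4ccc(F)cc4)ccc23)c1O`, 6840 nM
compound 2 `COc1ccc(F)cc1CNCCCNc1ccnc2cc(-c3ccc(F)cc3)ccc12`, 770 nM
compound 3 `COc1ccc(F)cc1CNCCCNc1ccnc2cc(CCc3ccccc3)ccc12`, 4240 nM

In an ADME assay on HepG2 cells (Homo sapiens) for cytotoxicity, read by luminescence, CellTiter-Glo and ATP content, with a stated time of 72 h (on this read-out lower numbers stand for an effect already at smaller amounts and higher numbers for an effect only at larger amounts of compound), compound 2 gives 770 nM. Compound 1 differs from it only at one place, (2-hydroxy-3-methoxyphenyl in place of 5-fluoro-2-methoxyphenyl on a saturated chain carbon bound to an amine nitrogen), and this change gave an 8.9-fold higher number from compound 2 to compound 1 (0.95 log units; beyond the scatter). Compound 3 differs from compound 2 at the core instead, (phenethyl in place of 4-fluorophenyl on an aromatic carbon), and this step read a 5.5-fold higher number from compound 2 to compound 3 (0.74 log units; beyond the scatter). Compound 4 `COc1cccc(CNCCCNc2ccnc3cc(CCc4ccccc4)ccc23)c1O` has not been measured; it carries the same change as compound 1, now made on the core of compound 3, (2-hydroxy-3-methoxyphenyl in place of 5-fluoro-2-methoxyphenyl on a saturated chain carbon bound to an amine nitrogen), at the same place. Because the earlier step was an 8.9-fold higher number from compound 2 to compound 1 (0.95 log units; beyond the scatter), a step of similar size is expected here, a 7.1-fold higher number from compound 3 to compound 4 (0.85 log units; beyond the scatter), resting on that single precedent alone. Compound 4 is therefore expected to give 30000 nM in this assay, with a range of 10000 nM to 90000 nM.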

Compound 4, half-maximal effective concentration: 6800 nM
Estimate against measurement, compound 4: 4.4-fold (0.64 log units) above; the measured number lies below the stated range.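

In this assay, the change to 2-hydroxy-3-methoxyphenyl on the core of compound 3 gave a 1.6-fold higher number from compound 3 to compound 4 (0.21 log units; within the scatter), so it did not carry over at the size seen on the core of compound 2: the same change on two cores in this assay, an 8.9-fold higher number (0.95 log units; beyond the scatter) from compound 2 to compound 1 and a 1.6-fold higher number (0.21 log units; within the scatter) from compound 3 to compound 4, 5.5-fold (0.74 log units) apart, beyond the scatter of two such steps. Read the other way, phenethyl in place of 4-fluorophenyl gave a 1.0-fold lower number from compound 1 to compound 4 (0.00 log units; within the scatter), and this step also departs from its earlier counterpart: the same change on two cores in this assay, a 5.5-fold higher number (0.74 log units; beyond the scatter) from compound 2 to compound 3 and a 1.0-fold lower number (0.00 log units; within the scatter) from compound 1 to compound 4, 5.5-fold (0.74 log units) apart, beyond the scatter of two such steps. The two changes therefore do not add up independently in these four compounds, but a single pair of cores shows neither why this happens nor how the change would behave on a further core.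

The compounds shown leave open which part of the 2-hydroxy-3-methoxyphenyl group accounts for the step on the core of compound 2. As far as these compounds go, it also remains open whether the same pattern would hold with a cyclohexyl group on that aromatic carbon or with a longer chain carrying the amine.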